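Nitrofuran Amides on Vero Cells: A Cytotoxicity Comparison

The compounds below may be only part of what the source reports. "The series", "measured", "known", "first", "only" and "open" are said of these compounds alone.

Measured so far in an ADME assay on Vero cells (Chlorocebus sabaeus) for cytotoxicity, read by MTT assay, with a stated time of 48 h; on this read-out lower numbers stand for higher toxicity in this test and higher numbers for lower toxicity in this test:
Compound 1, `CC(C)(NC(=O)c1ccc([N+](=O)[O-])o1)c1ccc(Cl)cc1`, gives 81000 nM.
Compound 2, `CC(C)(NC(=O)c1ccc([N+](=O)[O-])o1)c1ccc(OC(F)(F)F)cc1`, gives 70000 nM.
Compound 3, `CC(C)(NC(=O)c1ccc([N+](=O)[O-])o1)c1ccc(COc2ccccc2Cl)cc1`, gives 30000 nM.

The three measured compounds share one core and differ only in the group on the outer aromatic ring. Between compound 1 and compound 2 the change is trifluoromethoxy in place of chloro on an aromatic carbon, and it made a 1.2-fold lower number from compound 1 to compound 2 (0.06 log units; within the scatter). Between compound 1 and compound 3 the change is (2-chlorophenoxy)methyl in place of chloro on an aromatic carbon, and it made a 2.7-fold lower number from compound 1 to compound 3 (0.43 log units; beyond the scatter). Compound 2 and compound 3 are separated by a 2.3-fold lower number from compound 2 to compound 3 (0.37 log units; beyond the scatter). Compound 3 thus holds the lowest number of the three in this assay, with both of its steps beyond the scatter.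

Compound 4, `CC(C)(NC(=O)c1ccc([N+](=O)[O-])o1)c1ccc(COc2ccccc2OC(F)(F)F)cc1`, has not yet been measured in this assay. Among the compounds with values here, it differs from compound 3 by trifluoromethoxy in place of chloro on an aromatic carbon, which is the same kind of change as the one between compound 1 and compound 2. The two are not the same change, though: in the earlier pair the place is para to a large group, whereas here it is ortho to a large group, on the added ring rather than on the ring that carries the core.

Because the earlier instance gave a 1.2-fold lower number from compound 1 to compound 2 (0.06 log units; within the scatter), compound 4 is expected to sit close to compound 3, with a step of about a 1.2-fold lower number from compound 3 to compound 4 (0.08 log units; within the scatter). Compound 4 is therefore estimated at 25000 nM in this assay, with a range from 12000 nM to 50000 nM to allow for the different place of the change.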

Compound 4, half-maximal cytotoxic concentration: 13000 nM
Estimate against measurement, compound 4: 1.9-fold (0.28 log units) above, and the stated range covers the measured number.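

In this assay, putting trifluoromethoxy in place of chloro on the added ring, ortho to a large group, made a 2.3-fold lower number from compound 3 to compound 4 (0.36 log units; beyond the scatter). Set beside the earlier instance of the same change on the ring that carries the core, this step cannot be told apart from it: the same change on two cores in this assay, a 1.2-fold lower number (0.06 log units; within the scatter) from compound 1 to compound 2 and a 2.3-fold lower number (0.36 log units; beyond the scatter) from compound 3 to compound 4, 2.0-fold (0.30 log units) apart, within the scatter of two such steps. Within the data shown here, the pair therefore gives no ground for saying that the change behaves differently on the two cores, but it does not show that the change carries over with a fixed size, since there are only two instances, they sit in different places, and only the one from compound 3 to compound 4 lies beyond the scatter on its own.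

The compounds shown leave open whether the same change keeps its size on further cores, and whether the place on the ring matters at all, since place and core differ together in this pair. They also leave open how this assay would read for a different group in that spot on the added ring, such as an amine, a carboxylic acid or a longer alkyl chain.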